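The compounds below may be only part of what the source reports. "The series", "measured", "known", "first", "only" and "open" are said of these compounds alone.

Compound 1 `COc1ccc(C(c2ccccc2O)c2cccc3ccccc23)c(OC)c1OC` carries a 2-hydroxyphenyl group on a saturated chain carbon bound to two aromatic carbons. In a functional assay on THP-1 cells (Homo sapiens) for inhibition, read by sulforhodamine B assay, with a stated time of 48 h (on this read-out lower numbers stand for stronger inhibition and higher numbers for weaker inhibition), compound 1 reaches only the limit of the test, > 20000 nM. Compound 2 `COc1ccc(/C(=N/OC(C)=O)c2cccc3ccccc23)c(OC)c1OC` also stops at the limit in this assay, > 20000 nM. Compound 3 `COc1ccc(C(c2ccc(OC(C)CN(C)C)cc2)c2cccc3ccccc23)c(OC)c1OC` gives a measured value of 15000 nM in this assay. Compound 1 thus sits at the limit of > 20000 nM in this assay, at which 2 of the 3 values shown sit, with no number to compare against. Compound 4 `COc1ccc(C(OCc2ccccc2)c2cccc3ccccc23)c(OC)c1OC` differs from compound 1 by benzyloxy in place of 2-hydroxyphenyl on a saturated chain carbon bound to two aromatic carbons. Going by the values given here, no measured pair shows such a change, so the step from compound 1 to compound 4 is expected to stay within the scatter, with the limit the most likely outcome; the expected step is a step that the limit leaves unreadable from compound 1 to compound 4. Compound 4 is estimated at 25000 nM, within 10000 nM to 60000 nM.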

Compound 4, half-maximal inhibitory concentration: > 20000 nM
Compound 4: no number, only a limit (the forecaster's own chance of this, stated with the estimate: 70%); the middle value lies beyond the limit too.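

Going by these compounds alone, compound 4, like compound 1, stops at the limit of the test, so no step between the two can be read. Going by these compounds, whether benzyloxy in place of 2-hydroxyphenyl changes inhibition at all, and by how much, remains open.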